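The compounds below may be only part of what the source reports. "The series", "measured", "known", "first", "only" and "open" are said of these compounds alone.

Working notes on the thiazolidinone amides.

Compound 1 `COc1ccc(C)cc1N1C(=O)CSC1c1cccc(C(=O)NCCCCc2ccccc2)c1` carries a 2-methoxy-5-methylphenyl on the amide-type nitrogen of the five-membered ring and a phenylbutyl amide chain. Among the compounds with values here, in a functional assay on HOS-TE85 cells (Homo sapiens) for inhibition, read by CCK-8 assay, with a stated time of 72 h (on this read-out higher numbers stand for weaker inhibition and lower numbers for stronger inhibition), compound 1 gives 300 nM, the highest of the two numbers so far. Compound 2 `O=C(NCCCCn1cccn1)c1cccc(C2SCC(=O)N2c2cc(Br)ccn2)c1`, with a 4-bromopyridin-2-yl on the ring nitrogen and a pyrazolylbutyl chain, gives 105 nM in this assay, a lower number than compound 1 by a margin beyond the scatter. Compound 3 `O=C(NCCCCn1cccn1)c1cccc(C2SCC(=O)N2c2cccnc2)c1` reaches only the limit > 1000 nM in this assay; this is a limit of the assay, not a number (the limit of > 1000 nM in this assay, at which 1 of the 3 values shown sits). Within the data shown here, the one measured step, an at least 9.5-fold higher number from compound 2 to compound 3 (0.97 log units; beyond the scatter), shows that the group on the ring nitrogen can move the read-out by a large amount.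

Compound 4 `O=C(NCCCCc1ccccc1)c1cccc(C2SCC(=O)N2c2ccccn2)c1` is the next entry: pyridin-2-yl in place of 2-methoxy-5-methylphenyl on an amide-type nitrogen in a ring. Among the measured compounds shown here, no measured step covers this exact exchange; the step from compound 2 to compound 3 concerns a different pair of rings, and the phenylbutyl chain of compound 1 is kept. A pyridin-2-yl is shared with the bromo analogue compound 2, whose value 105 nM is the best seen, so a modest move toward lower numbers is expected, with wide uncertainty. Compound 4 is estimated at 220 nM, within 70 nM to 800 nM, an expected step of a 1.4-fold lower number from compound 1 to compound 4 (0.13 log units; within the scatter).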

Compound 4, half-maximal inhibitory concentration: 19.7 nM
The estimate for compound 4 lay 11-fold (1.05 log units) above the measured number; the measured number lies below the stated range.
By their numbers in this assay, from the lowest: compound 4; then compound 2; then compound 1. At a limit, above all of these: compound 3.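

In this assay the exchange on the amide-type nitrogen in the ring gives a large move (a 15-fold lower number from compound 1 to compound 4 (1.18 log units; beyond the scatter)). Within the data shown here, this position therefore moves the read-out strongly with the phenylbutyl chain as well, whereas the only earlier measured step (an at least 9.5-fold higher number from compound 2 to compound 3 (0.97 log units; beyond the scatter)) came from the pyrazolylbutyl chain. A pyridin-2-yl with no further group on it is enough for a low number with this chain, and neither the methoxy nor the methyl group of compound 1 is required for that; nothing measured here gives a reason for the size of the step.

The exchange removes the methoxy and the methyl group and brings in a ring nitrogen all at once, so the step does not say which of these changes counts, and a plain phenyl or a 2-methoxyphenyl on the same nitrogen would be needed to separate them. Compound 2 and compound 4 differ in two places, the bromine and the chain, so the share of each in the gap between them cannot be read.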